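A few compounds are considered here, and "the series" means these few. Any claim that something is new, unique, unknown or untested is made for them only; others in the source may bear on it.

Working notes, ring-nitrogen aryl series.

Compound 2 `CC(F)(F)c1cccc(N2C(=O)CSC2c2cccc(C(=O)NCCCCc3ccccc3)c2)c1` stands level with compound 1 `O=C(NCCCCc1ccccc1)c1cccc(C2SCC(=O)N2c2ccccc2F)c1` on the one read-out in hand: in a functional assay on MG-63 cells (Homo sapiens) for inhibition, read by CCK-8 assay, with a stated time of 72 h, tested at 1 uM (a higher number here means more inhibition at the concentration tested (going by the name of the read-out), a lower number less inhibition), compound 2 gives 92% and compound 1 gives 92%. Among the measured compounds shown here, the only measured step, no change at the digits printed from compound 1 to compound 2 (within the scatter), replaced the aryl group on the amide-type nitrogen of the ring with a larger fluorinated one and left inhibition where it was.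

Compound 3 `COc1c(F)cccc1N1C(=O)CSC1c1cccc(C(=O)NCCCCc2ccccc2)c1` alters the same position again: a group of 9 heavy atoms (7 carbon, 1 oxygen, 1 fluorine; one six-membered aromatic ring of carbon only) in place of a group of 10 heavy atoms (8 carbon, 2 fluorine; one six-membered aromatic ring of carbon only), on an amide-type nitrogen in a ring. For the measured compounds named here, that step bears directly on the one measured step, which was flat within the scatter, so the expectation for compound 3 in this assay is a step of about a number 4 percentage points lower from compound 2 to compound 3 (within the scatter) from compound 2, no change beyond the scatter in either direction. On these data alone, a 3-fluoro-2-methoxyphenyl group here is untested, so the range stays wide. For compound 3 in this assay an estimate of 88% is expected, within 72% to 97%.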

Compound 3, a percentage reported as inhibition, at one concentration (the size of the read-out at that concentration, not a potency): 0%
Compound 3: middle estimate off by 88 percentage points, on the high side; measured number outside the range, below it.
By their numbers in this assay, from the lowest: compound 3; then compounds 1 and 2 (each within the scatter of the next).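

The inhibition read-out does not stay level across aryl groups on the amide-type nitrogen in a ring: in this assay, the change to 3-fluoro-2-methoxyphenyl gives a number 92 percentage points lower from compound 2 to compound 3 (beyond the scatter), and the same group in place of 2-fluorophenyl gives a number 92 percentage points lower from compound 1 to compound 3 (beyond the scatter). Compound 1 and compound 3 both carry a fluorine on this aryl ring, so a fluorine on the ring does not by itself secure inhibition here, and the flat first step does not extend to every aryl group at this position. Nothing at hand explains the loss.

The compounds shown leave open whether the methoxy group alone accounts for the loss or only its combination with the fluorine. A 2-methoxyphenyl group without fluorine, or a 2-aminophenyl group, would help separate these readings.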